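This account rests on a few compounds, and the source may have more. Where it says the series, first, only, none or still open, it means among the compounds named here.

Measured so far:

- compound 1, `CC(Oc1ccc(Oc2ccc(F)cc2)cc1)C(=O)Cn1nnc(-c2ccc(Cl)cc2)n1`: 42 nM
- compound 2, `CC(Oc1ccc(Oc2ccc(Cl)cc2)cc1)C(=O)Cn1nnc(-c2ccc(Cl)cc2)n1`: 76 nM
- compound 3, `CC(Oc1ccc(Oc2ccc(F)cc2)cc1)C(=O)Cn1nnc(-c2ccc(C(=O)O)cc2)n1`: 100 nM

All three were tested in an assay on microsomes from brain for inhibition of Fatty-acid amide hydrolase 1 (Rattus norvegicus), read by fluorescence and HPLC, with a stated time of 60 min; on this read-out higher numbers stand for weaker inhibition and lower numbers for stronger inhibition. Compound 1 and compound 2 share one core, and they differ in a single place: chloro in place of fluoro on an aromatic carbon. That change gives a 1.8-fold higher number from compound 1 to compound 2 (0.26 log units; within the scatter), a step too small to be trusted on its own.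

Compound 3 carries a different core from compound 1, and the difference between the two cores is counted as carboxy in place of chloro on an aromatic carbon. It produced a 2.4-fold higher number from compound 1 to compound 3 (0.38 log units; beyond the scatter). Compound 3 and compound 2 are close to each other in this assay, so no order between them can be drawn.

Compound 4, `CC(Oc1ccc(Oc2ccc(Cl)cc2)cc1)C(=O)Cn1nnc(-c2ccc(C(=O)O)cc2)n1`, has not yet been measured. It stands to compound 3 exactly as compound 2 stands to compound 1: the difference is chloro in place of fluoro on an aromatic carbon, and the surroundings of the changed place are described in the same words in both pairs, so this is the same change seen again, now on the core of compound 3.

Among the measured compounds shown here, the only guide to what it will do is the earlier pair. Since that pair gave a 1.8-fold higher number from compound 1 to compound 2 (0.26 log units; within the scatter), a step of about the same size is expected here, that is a 1.6-fold higher number from compound 3 to compound 4 (0.20 log units; within the scatter), resting on the assumption that the change behaves alike on both cores. Compound 4 is therefore estimated at 160 nM, with a likely range from 70 nM to 380 nM.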

Compound 4, half-maximal inhibitory concentration: 90 nM
Beside the measured number, compound 4's estimate is 1.8-fold (0.25 log units) above it; the measured number falls inside the stated range.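

In this assay, putting chloro in place of fluoro on the core of compound 3 gives a 1.1-fold lower number from compound 3 to compound 4 (0.05 log units; within the scatter), a step too small to count as a real change, and it cannot be told apart from the same swap on the core of compound 1: the same change on two cores in this assay, a 1.8-fold higher number (0.26 log units; within the scatter) from compound 1 to compound 2 and a 1.1-fold lower number (0.05 log units; within the scatter) from compound 3 to compound 4, 2.0-fold (0.30 log units) apart, within the scatter of two such steps. Putting carboxy in place of chloro, read this time on the core of compound 2, gives a 1.2-fold higher number from compound 2 to compound 4 (0.07 log units; within the scatter), and although the earlier step for this change lay beyond the scatter and this one does not, the two still cannot be separated: the same change on two cores in this assay, a 2.4-fold higher number (0.38 log units; beyond the scatter) from compound 1 to compound 3 and a 1.2-fold higher number (0.07 log units; within the scatter) from compound 2 to compound 4, 2.0-fold (0.30 log units) apart, within the scatter of two such steps. So nothing here shows either change behaving differently from one core to the other, but this does not prove that they behave alike, since each comparison rests on a single pair per core and a real difference of modest size could stay hidden in the scatter.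

Going by these compounds, what a methoxy group or a nitrile would do in place of the fluoro or chloro remains open, as does an amine in place of the carboxy. Whether such groups would carry from one core to the other as these changes appear to is also unanswered by these four compounds.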